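The source may hold more compounds than are shown below. What is called first, only, known or untested is meant among the compounds shown, and "the series" means these compounds.

Measured so far in a physicochemical assay for lipophilicity, at pH 7.4; a lower number here means a more polar compound, a higher number a more lipophilic compound

- Compound 1 `CC(=O)CCc1cc(C)c(Oc2cc(Nc3ccc(C#N)cc3)c(N)cc2C(F)(F)F)c(C)c1` gives > 5 which is a limit of the assay, not a number.
- Compound 2 `Cc1cc(CCC#N)cc(C)c1Oc1cc(Nc2ccc(C#N)cc2)c(N)cc1CO` gives 3.68 as the only actual number.

Compound 2 therefore has no numerical neighbour, since the other result is the limit of > 5 in this assay, at which 1 of the 2 values shown sits, and gives no exact position. Compound 3 `Cc1cc(CCC#N)cc(C)c1Oc1cc(Nc2ccc(C#N)cc2)c(N)cc1C(F)(F)F` carries trifluoromethyl in place of hydroxymethyl on an aromatic carbon and awaits measurement. For the measured compounds named here, no measured pair shows this change. A higher number is expected, resting on compound 1, which carries trifluoromethyl and whose > 5 is a limit. The expected move is a number 1.12 log units higher from compound 2 to compound 3 (beyond the scatter) and lies beyond the scatter. For compound 3 the estimate is 4.8 with an expected range of 4.3 to 5.2 in this measurement.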

Compound 3, partition coefficient: > 5
Compound 3: only a limit was reported (the forecaster's own chance of this, stated with the estimate: 35%); middle value at least 0.20 log units away from the limit.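

In this assay, trifluoromethyl in place of hydroxymethyl on this aromatic carbon, para to a (4-cyanophenyl)amino group, gives a number at least 1.32 log units higher from compound 2 to compound 3 (beyond the scatter). For the compounds shown here, this is the first measured pair that differs only in this place, so the change now has a direct reading. Compound 3 gives a limit and not a number, so its full step stays unknown, and the step between compound 1 and compound 3 cannot be read because both results are limits: the limit of > 5 in this assay, at which 2 of the 3 values shown sit.

The compounds shown leave open how far past the limit compound 3 lies. They also leave open where a methyl, a methoxy or an amine on this carbon would fall in this assay.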